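Swapping the sulfonyl substituent: from azido to benzylamino

The source may hold more compounds than are shown below. What is called first, only, known or untested is meant among the compounds shown, and "the series" means these compounds.

Of the compounds shown here, two of a shared core have been measured so far. Compound 1 `CC1(C)C=C(n2ccccc2=O)c2cc(S(=O)(=O)N=[N+]=[N-])ccc2O1` carries an azido group on its sulfonyl sulfur, and in a functional assay on the whole organism (trachea) with Rattus norvegicus as the target (on this read-out lower numbers stand for smaller maximal responses and higher numbers for larger maximal responses), compound 1 gives 77.2%. Compound 2 `CNS(=O)(=O)c1ccc2c(c1)C(n1ccccc1=O)=CC(C)(C)O2` carries a methylamino group in that place, and in this assay compound 2 gives 83%. On the numbers shown, compound 1 stands lowest of the two, but the difference to compound 2 is small: a number 5.8 percentage points higher from compound 1 to compound 2 (within the scatter).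

Compound 3 `CC1(C)C=C(n2ccccc2=O)c2cc(S(=O)(=O)NCc3ccccc3)ccc2O1` is not yet measured. It differs from compound 1 in a single place: benzylamino in place of azido on a sulfonyl sulfur. Among the measured compounds shown here, the only measured step that bears on this change is the one from compound 1 to compound 2, where a small amino group also replaced the azido group, and that step stayed within the scatter. A larger amino group now takes the same place, and the data give no way to tell whether its size matters here. The step from compound 1 to compound 3 is therefore expected to be a number 2.8 percentage points higher from compound 1 to compound 3 (within the scatter), no movement beyond the scatter in either direction. Compound 3 is expected to give 80%, between 65% and 95%.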

Compound 3, largest response reached (Emax), in percent of the reference or control that the assay uses: 77.5%
Beside the measured number, compound 3's estimate is 2.5 percentage points above it; low and high end bracket the measured number.
By their numbers in this assay, from the lowest: compounds 1, 3 and 2 (each within the scatter of the next).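

Placing benzylamino on the sulfonyl sulfur brings in a group of 8 heavy atoms with a six-membered aromatic ring where azido had 3 heavy atoms and no ring, yet in this assay this change gives a number 0.3 percentage points higher from compound 1 to compound 3 (within the scatter). The earlier compounds shown here showed this only for the small methylamino group, whereas phenyl in place of hydrogen on the saturated chain carbon bound to the sulfonamide nitrogen now gives a number 5.5 percentage points lower from compound 2 to compound 3 (within the scatter), so azido, methylamino and benzylamino all stay within the scatter of one another on this sulfur. Nothing available here offers an explanation for this lack of separation.

The three groups shown leave open whether any group on this sulfur can move the maximal response beyond the scatter, for example a plain amino group, a dimethylamino group, or a longer chain such as phenylethylamino. A carboxylic acid on the chain carbon bound to the sulfonamide nitrogen, in place of the phenyl of compound 3, also remains an open case for this read-out.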